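Removing the Chloro Where Every Value Is a Limit

The source may report more compounds than this note shows. Statements on the series, on what has been measured and on what is new or still open speak of the compounds shown alone.

The measured compounds:
compound 1, `COc1cc(/C=C/C(=O)c2sc(Nc3cccc(Cl)c3)nc2C)cc(OC)c1OC`; in a functional assay on NCI-H460 cells (Homo sapiens) for cytotoxicity, read by MTT assay (a higher number here means a weaker inhibitor, a lower number a stronger inhibitor), compound 1 gives > 25000 nM
compound 2, `Cc1ccccc1Nc1nc(C)c(C(=O)/C=C/c2ccccc2)s1`; in this assay compound 2 gives > 25000 nM
compound 3, `Cc1nc(Nc2ccc(Cl)c(Cl)c2)sc1C(=O)/C=C/c1ccc(Cl)cc1`; in this assay compound 3 gives > 25000 nM

The value of compound 1 is a limit of the assay, not a number. The value of compound 2 is a limit as well. The value of compound 3 is also a limit. Going by the values given here, compound 1 therefore stands at the limit of > 25000 nM in this assay, at which 3 of the 3 values shown sit, and the two other values stand at that same limit, so no ranking among the three is possible and no step between measured compounds that differ in one place is available.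

Compound 4, `COc1cc(/C=C/C(=O)c2sc(Nc3ccccc3)nc2C)cc(OC)c1OC`, differs from compound 1 by hydrogen in place of chloro on an aromatic carbon, the change read one bond further out as 3-chlorophenyl to phenyl.

With every measured value sitting at the limit of > 25000 nM in this assay, at which 3 of the 3 values shown sit, there is no evidence that such a change moves the read-out in either direction. The step from compound 1 to compound 4 is expected to be a step that the limit leaves unreadable from compound 1 to compound 4, none beyond the scatter. Compound 4 is therefore estimated at 40000 nM in this assay, with a range from 15000 nM to 150000 nM, most likely reported again only as a limit.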

Compound 4, half-maximal inhibitory concentration: > 25000 nM
Compound 4: a limit, no number; the forecaster's own chance of this, stated with the estimate: 85%; the middle value does not contradict the limit.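

Going by these compounds alone, the result for compound 4 in this assay is a limit, as is that of compound 1, so no step between compound 1 and compound 4 can be read: the limit of > 25000 nM in this assay, at which 4 of the 4 values shown sit. The compounds shown leave open whether hydrogen in place of chloro on an aromatic carbon changes the read-out at all, and at what concentration any of the four would reach half-maximal inhibition.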